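The compounds below may be only part of what the source reports. "The series", "measured", "known", "first", "only" and "open" are said of these compounds alone.

Two compounds share one core and differ only at an oxygen on an aromatic ring. In an assay on membranes from brain for displacement of a labelled ligand from Sigma non-opioid intracellular receptor 1 (Cavia porcellus), read by scintillation counting, with a stated time of 90 min (a higher number here means a weaker inhibitor, a lower number a stronger inhibitor), compound 1 `COc1cccc(Cn2cc(C(=O)NCCCCN3CCc4cc(OC)c(OC)cc4C3)nn2)c1` gives 12700 nM. Compound 2 `COc1cc2c(cc1OC)CN(CCCCNC(=O)c1cn(Cc3cccc(O)c3)nn1)CC2` in this assay gives 8080 nM, the low end of the two numbers shown, with compound 1 as its only neighbour and the gap between them within the scatter. Among the measured compounds shown here, the single measured step, a 1.6-fold lower number from compound 1 to compound 2 (0.20 log units; within the scatter), puts hydrogen in place of methyl on that oxygen. Compound 3 `COc1cc2c(cc1OC)CN(CCCCNC(=O)c1cn(Cc3cccc(OCCF)c3)nn1)CC2` carries the change (2-fluoroethyl in place of hydrogen on an oxygen on an aromatic ring), a 2-fluoroethyl in place of hydrogen on an oxygen on an aromatic ring whose other neighbour is aromatic carbon. Only a 1.6-fold lower number from compound 1 to compound 2 (0.20 log units; within the scatter) bears on this, and it stayed within the scatter, so for compound 3 a step of about a 1.4-fold higher number from compound 2 to compound 3 (0.13 log units; within the scatter) in this assay is expected, leaning toward the number of compound 1. The estimate for compound 3 in this assay is 11000 nM, with a range from 4000 nM to 30000 nM.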

Compound 3, inhibition constant: 46300 nM
Compound 3: middle estimate off by 4.2-fold (0.62 log units), on the low side; measured number outside the range, above it.
By their numbers in this assay, from the lowest: compounds 2 and 1 (each within the scatter of the next); then compound 3.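

In this assay, methyl and hydrogen on the oxygen on the aromatic ring stayed within the scatter of each other, but this position does respond to a larger group: 2-fluoroethyl in place of hydrogen gives a 5.7-fold higher number from compound 2 to compound 3 (0.76 log units; beyond the scatter). Measured against the methyl ether, the fluoromethyl in place of hydrogen on the saturated chain carbon gives a 3.6-fold higher number from compound 1 to compound 3 (0.56 log units; beyond the scatter), so the rise in the number appears from both neighbours and does not depend on the free hydroxy alone. Nothing available explains these steps.

The compounds shown leave open whether the fluorine or the two-carbon chain carries the step, a question that a plain ethyl on the same oxygen would address. Going by these compounds, how a longer chain such as 3-fluoropropyl, or a chain ending in an amine, would read at this oxygen also stays open.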